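The source may report more compounds than this note shows. Statements on the series, on what has been measured and on what is new or still open speak of the compounds shown alone.

Compound 1 `c1ccc2c(c1)CN[C@@H](CN(CCCCNC1CCOCC1)[C@H]1CCCc3cccnc31)C2` was tested in a functional assay on cells for agonist activity at C-X-C chemokine receptor type 4 (Homo sapiens), read by fluorescence and calcium flux, with a stated time of 90 s; a lower number here means that less compound is needed, a higher number that more compound is needed for the effect. In this assay compound 1 gives > 30000 nM, which is a limit of the assay rather than a number. For the measured compounds named here, compound 2 `C(=C/CN(C[C@H]1Cc2ccccc2CN1)[C@H]1CCCc2cccnc21)\CNCC1CCOCC1` is the one measured neighbour of compound 1. In this assay compound 2 gives > 30000 nM, again a limit. Going by the values given here, the step that the two limits leave unreadable from compound 1 to compound 2 is therefore not readable, and the one thing the two values show is the limit of > 30000 nM in this assay, at which 2 of the 2 values shown sit. Compound 3 `CC(C)(CCN(C[C@H]1Cc2ccccc2CN1)[C@H]1CCCc2cccnc21)CNC1CCOCC1` differs from compound 1 as follows: a group of 11 heavy atoms (9 carbon, 1 nitrogen, 1 oxygen; one six-membered non-aromatic ring with 1 hetero atom) in place of a group of 9 heavy atoms (7 carbon, 1 nitrogen, 1 oxygen; one six-membered non-aromatic ring with 1 hetero atom), on a saturated chain carbon, two bonds along the chain from an amine nitrogen. The measured step changes a group on a saturated chain carbon bound to an amine nitrogen, while the change to compound 3 sits on a saturated chain carbon two bonds along the chain from an amine nitrogen, so the measured step does not directly cover it, and its size cannot be read anyway. Since both measured values sit at the limit, compound 3 is expected to sit there too, with a step that the limit leaves unreadable from compound 1 to compound 3 expected to be close to none. Compound 3 is estimated at 40000 nM, with a range from 15000 nM to 100000 nM.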

Compound 3, half-maximal effective concentration: > 30000 nM
Compound 3 ended at the assay's limit (the forecaster's own chance of this, stated with the estimate: 80%); the middle value does not contradict the limit.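

Compound 3 gives > 30000 nM, again a limit of this assay and not a number, so the step from compound 1 to compound 3 cannot be read. The result adds one more compound at this limit: the limit of > 30000 nM in this assay, at which 3 of the 3 values shown sit.

On these data alone, whether any of these chain changes alters the activity, and by how much, remains open.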